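The compounds below may be only part of what the source reports. "The series", "measured", "known", "first", "only" and "open" are said of these compounds alone.

Working notes on the bis-sulfonamide series.

Of the compounds shown here, three have numbers so far. Compound 1 `COc1ccc(S(=O)(=O)Nc2ccc3oc(-c4ccc(NS(=O)(=O)c5cc(F)ccc5OC)cc4)nc3c2)cc1` gives 15000 nM in a functional assay on HCT-116 cells (Homo sapiens) for cytotoxicity, read by resazurin assay, with a stated time of 48 h; on this read-out higher numbers stand for an effect only at larger amounts of compound and lower numbers for an effect already at smaller amounts. Compound 2 `O=S(=O)(Nc1ccc(-c2nc3cc(NS(=O)(=O)c4ccc(Br)cc4)ccc3o2)cc1)c1ccc(Br)cc1` gives 11000 nM in this assay. Compound 3 `Nc1ccc(S(=O)(=O)Nc2ccc(-c3nc4cc(NS(=O)(=O)c5ccc(N)cc5)ccc4o3)cc2)cc1` gives 17000 nM in this assay. Compound 1 stands second highest of the three numbers; its nearest neighbour is compound 3 and its furthest neighbour is compound 2, and both gaps lie within the usual scatter, so the three numbers cannot be separated from one another on this read-out.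

Compound 4 `COc1ccc(S(=O)(=O)Nc2ccc(-c3nc4cc(NS(=O)(=O)c5ccc(OC)cc5)ccc4o3)cc2)cc1` has not yet been measured in this assay. It differs from compound 1 in one place: 4-methoxyphenyl in place of 5-fluoro-2-methoxyphenyl on a sulfonyl sulfur. With this change compound 4 carries the same 4-methoxyphenyl group on both sulfonyl sulfurs, so its two sulfonamide arms match each other, as do the arms of compound 2 and of compound 3.

Among the compounds with values here, no step between measured compounds is known, and the three numbers in hand lie within the scatter of one another, so they give no direction for the change. The step from compound 1 to compound 4 is therefore expected to be a 1.1-fold lower number from compound 1 to compound 4 (0.03 log units; within the scatter), none beyond the scatter. For compound 4 in this assay the estimate is 14000 nM, with a range from 6000 nM to 32000 nM.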

Compound 4, half-maximal effective concentration: 12000 nM
Estimate against measurement, compound 4: 1.2-fold (0.07 log units) above; low and high end bracket the measured number.
By their numbers in this assay, from the lowest: compounds 2, 4, 1 and 3 (each within the scatter of the next).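

In this assay, within the data shown here, the exchange of 5-fluoro-2-methoxyphenyl for 4-methoxyphenyl on a sulfonyl sulfur gives the first step that can be read: a 1.3-fold lower number from compound 1 to compound 4 (0.10 log units; within the scatter). This single change, which leaves the two sulfonamide arms of compound 4 matching, cannot be told apart from no change on this read-out, so the two aryl groups are not separated here. No measurement offered bears on why the number stays within the scatter.

Steps from compound 4 to compound 2 or compound 3 cannot be read, as those compounds differ from it in both arms, so the bromo and amino groups give no separate information on either sulfonyl sulfur. Open, as far as these compounds go, is whether any group at this place moves the number beyond the scatter, for example a carboxylic acid on the phenyl ring, or a methyl group or a piperidine ring on the sulfonyl sulfur in place of the aryl group.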